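The source may report more compounds than this note shows. Statements on the series, on what has been measured and on what is new or still open speak of the compounds shown alone.

The shared core is that of compound 1 `N#Cc1ccc(/C=N/NC(=O)Nc2ccc(Oc3ccnc4[nH]ccc34)c(F)c2)cc1`, which in a functional assay on HepG2 cells (Homo sapiens) for antiproliferative activity, read by MTT assay, with a stated time of 72 h (a higher number here means a weaker inhibitor, a lower number a stronger inhibitor), gives 850 nM, the lowest of the three measured numbers. Compound 2 `O=C(N/N=C/c1ccc(Cl)c(Cl)c1)Nc1ccc(Oc2ccnc3[nH]ccc23)c(F)c1` gives 3700 nM in this assay, and compound 3 `O=C(N/N=C/c1ccc(O)cc1O)Nc1ccc(Oc2ccnc3[nH]ccc23)c(F)c1` gives 4550 nM. Both measured steps away from compound 1 move the number up: a 4.4-fold higher number from compound 1 to compound 2 (0.64 log units; beyond the scatter), and a 5.4-fold higher number from compound 1 to compound 3 (0.73 log units; beyond the scatter). Between the other two, a 1.2-fold higher number from compound 2 to compound 3 (0.09 log units; within the scatter), so compound 2 and compound 3 are not separated.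

Compound 4 `O=C(N/N=C/c1cc(Br)c(O)c(Br)c1)Nc1ccc(Oc2ccnc3[nH]ccc23)c(F)c1` has not yet been measured in this assay. Relative to compound 1 the change is 3,5-dibromo-4-hydroxyphenyl in place of 4-cyanophenyl on a carbon with a double bond to nitrogen. Both prior replacements of the 4-cyanophenyl bear on this: in compound 2 the entering ring carries two chlorines, in compound 3 two hydroxyls, and each gave a modest rise beyond the scatter. Among the measured compounds shown here, the 3,5-dibromo-4-hydroxyphenyl of compound 4 carries both a pair of halogens and a hydroxyl, so a rise of comparable size is expected, a 4.1-fold higher number from compound 1 to compound 4 (0.61 log units; beyond the scatter), rather than no step or a fall. Compound 4 is therefore expected to give about 3500 nM in this assay, within a range from 1200 nM to 10000 nM.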

Compound 4, half-maximal inhibitory concentration: 6520 nM
Estimate against measurement, compound 4: 1.9-fold (0.27 log units) below; the measured number falls inside the stated range.
By their numbers in this assay, from the lowest: compound 1; then compounds 2, 3 and 4 (each within the scatter of the next).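

In this assay the third replacement of the 4-cyanophenyl on a carbon with a double bond to nitrogen also moves the number up (a 7.7-fold higher number from compound 1 to compound 4 (0.88 log units; beyond the scatter)), so compound 1 stays the strongest inhibitor of the four, and no replacement shown goes against this direction. Two bromines and a hydroxyl on one ring do not separate compound 4 from the ring with two chlorines (a 1.8-fold higher number from compound 2 to compound 4 (0.25 log units; within the scatter)) or from the ring with two hydroxyls (a 1.4-fold higher number from compound 3 to compound 4 (0.16 log units; within the scatter)), so three differently substituted rings now form one group that compound 1 alone stands clear of. No measurement at hand accounts for these steps.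

The compounds shown leave open whether the low number of compound 1 belongs to the nitrile itself, which a 4-aminophenyl or a 4-carboxyphenyl in its place would begin to test. They also leave open whether a ring with a single chlorine or a single hydroxyl would stay with compounds 2, 3 and 4 or move toward compound 1.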